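From Isopropyl to sec-Butyl on a Shared Core

This account rests on a few compounds, and the source may have more. Where it says the series, first, only, none or still open, it means among the compounds named here.

compound 1, `C/N=C(\NC#N)Nc1cccnc1`: > 50 mg/kg
compound 2, `CC(C)/N=C(\NC#N)Nc1cccnc1`: 2.5 mg/kg

The two measured compounds share one core and differ only in the group on the double-bonded nitrogen. In a functional assay on the whole organism (blood, strain Wistar-Okamoto) with Rattus norvegicus as the target, with a stated time of 5 days (on this read-out higher numbers stand for an effect only at larger amounts of compound and lower numbers for an effect already at smaller amounts), compound 1 gives > 50 mg/kg, which is a limit of the assay and not a number. In this assay compound 2 gives 2.5 mg/kg. For the measured compounds named here, the one measured step, an at least 20-fold lower number from compound 1 to compound 2 (1.30 log units; beyond the scatter), is bounded from one side only because compound 1 sits at the limit of > 50 mg/kg in this assay, at which 1 of the 2 values shown sits. Compound 2 thus holds the only real number shown; the other value is a limit.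

Compound 3, `CCC(C)/N=C(\NC#N)Nc1cccnc1`, has not been measured. It differs from compound 2 by methyl in place of hydrogen on a saturated chain carbon, two bonds along the chain from a double-bonded nitrogen. The measured step bears on this change only loosely: it shows that a larger branch on the double-bonded nitrogen went with a much lower number, but it cannot tell whether one further methyl on that branch does anything more. The author expects no step beyond the scatter, no change at the digits printed from compound 2 to compound 3 (within the scatter). Compound 3 is estimated at 2.5 mg/kg, with a range from 0.8 mg/kg to 8 mg/kg.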

Compound 3, minimum effective dose: 20 mg/kg
For compound 3 the middle estimate is 8.0-fold (0.90 log units) below the measured one; measured number outside the range, above it.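

In this assay, the saturated chain carbon two bonds along the chain from a double-bonded nitrogen turns out not to be a neutral place for a methyl: methyl in place of hydrogen there goes with an 8.0-fold higher number from compound 2 to compound 3 (0.90 log units; beyond the scatter), so compound 3 goes against any reading of the earlier step as a rule that a larger group on that nitrogen brings a lower number. The change from methyl to sec-butyl on the double-bonded nitrogen still goes with an at least 2.5-fold lower number from compound 1 to compound 3 (0.39 log units; beyond the scatter), which places the sec-butyl group on the favourable side of methyl, though less far than isopropyl. Compound 1 holds a limit of the assay and not a number, and that step is bounded from one side only because of it: the limit of > 50 mg/kg in this assay, at which 1 of the 3 values shown sits.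

The compounds shown leave open whether the higher number follows the branch itself or simply the added length, which a straight propyl chain, a tert-butyl group or a cyclopropyl ring on the same nitrogen would bear on. They also give no cause for the step, and they say nothing about how far the trend would run with a longer chain.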